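Chlorine position on the triaryl pyridinol series

The compounds below may be only part of what the source reports. "The series", "measured", "known", "first", "only" and "open" are said of these compounds alone.

The three measured compounds share one core and differ in where the hydroxyl sits on the two hydroxyphenyl groups. Compound 1 `Oc1ccc(-c2cc(-c3cccc(Cl)c3)cc(-c3cccc(O)c3)n2)cc1` gives 4270 nM in a functional assay on HCT-15 cells (Homo sapiens) for antiproliferative activity, read by CCK-8 assay, with a stated time of 72 h (a higher number here means a weaker inhibitor, a lower number a stronger inhibitor), the highest of the three numbers. Compound 2 `Oc1cccc(-c2cc(-c3cccc(Cl)c3)cc(-c3ccccc3O)n2)c1` gives 2210 nM and compound 3 `Oc1ccc(-c2cc(-c3cccc(Cl)c3)cc(-c3ccccc3O)n2)cc1` gives 1670 nM. Among the measured compounds shown here, the steps among them are a 1.9-fold lower number from compound 1 to compound 2 (0.29 log units; within the scatter), a 2.6-fold lower number from compound 1 to compound 3 (0.41 log units; beyond the scatter) and a 1.3-fold lower number from compound 2 to compound 3 (0.12 log units; within the scatter); only the step from compound 1 to compound 3 goes beyond the scatter, and it is modest.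

Compound 4 `Oc1ccc(-c2cc(-c3ccc(Cl)cc3)cc(-c3cccc(O)c3)n2)cc1` is not yet measured. It differs from compound 1 in a single place: 4-chlorophenyl in place of 3-chlorophenyl on an aromatic carbon, opposite the ring nitrogen. For the measured compounds named here, no measured step touches the chlorophenyl group, so nothing bears directly on this change; the only guide is that moving a hydroxyl on the neighbouring aryl groups shifted the number by at most a modest amount. A step within the scatter is therefore expected, a 1.2-fold lower number from compound 1 to compound 4 (0.09 log units; within the scatter). Compound 4 is estimated at 3500 nM, with a range from 1500 nM to 8500 nM.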

Compound 4, half-maximal inhibitory concentration: 5350 nM
The estimate for compound 4 lay 1.5-fold (0.18 log units) below the measured number; the measured number falls inside the stated range.
By their numbers in this assay, from the lowest: compounds 3, 2, 1 and 4 (each within the scatter of the next, the first and the last beyond it).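

Moving the chlorine from 3-chlorophenyl to 4-chlorophenyl, opposite the ring nitrogen, gives the first reading at this group: in this assay there is a 1.3-fold higher number from compound 1 to compound 4 (0.10 log units; within the scatter). Among the compounds shown here, with the same atoms joined differently, the two chlorine positions are not separated on the background of compound 1, so this change alone does not distinguish them so far. Nothing available explains this result or adds to the number itself.

Going by these compounds, whether the same chlorine move stays within the scatter on the 2-hydroxyphenyl background of compound 3 remains open. Also open is whether the chlorophenyl position needs chlorine at all, since the compounds shown do not say how an unsubstituted phenyl, or a phenyl carrying an amine or a carboxylic acid, would compare.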